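Swapping ethyl for methoxy on the anilino ring

This account rests on a few compounds, and the source may have more. Where it says the series, first, only, none or still open, it means among the compounds named here.

Measured compounds, in a functional assay on MCF7 cells (Homo sapiens) for inhibition, read by sulforhodamine B assay; on this read-out lower numbers stand for stronger inhibition and higher numbers for weaker inhibition:
- Compound 1 `Cc1ccc(NC2=CC(=O)c3nc4n(c3C2=O)[C@H]2OC[C@@H](O)[C@H]2OC4)cc1C`: 2080 nM
- Compound 2 `O=C1C=C(NCc2ccccc2)C(=O)c2c1nc1n2[C@H]2OC[C@@H](O)[C@H]2OC1`: a limit of the assay, > 8000 nM
- Compound 3 `CCc1ccc(NC2=CC(=O)c3nc4n(c3C2=O)[C@H]2OC[C@@H](O)[C@H]2OC4)cc1`: 960 nM

Compound 3 holds the lowest number of the two measured outright, with compound 1 nearest, as the step of a 2.2-fold lower number from compound 1 to compound 3 (0.34 log units; beyond the scatter) shows; compound 2 gives only a limit, not a number (the limit of > 8000 nM in this assay, at which 1 of the 3 values shown sits). Moving from a benzyl group to an aromatic ring on the amine nitrogen mattered most, as seen in an at least 3.8-fold higher number from compound 1 to compound 2 (0.58 log units; beyond the scatter) and an at least 8.3-fold lower number from compound 2 to compound 3 (0.92 log units; beyond the scatter), while the change among aryl substituents was smaller, as in a 2.2-fold lower number from compound 1 to compound 3 (0.34 log units; beyond the scatter).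

Compound 4 `COc1ccc(NC2=CC(=O)c3nc4n(c3C2=O)[C@H]2OC[C@@H](O)[C@H]2OC4)cc1` keeps the aromatic ring and differs from compound 3 only in the group para to the large group: methoxy in place of ethyl on an aromatic carbon. Going by the values given here, none of the measured steps swaps an alkyl for a methoxy group, so the nearest guide is the modest size of a 2.2-fold lower number from compound 1 to compound 3 (0.34 log units; beyond the scatter). Since compound 4 retains the aryl amine that drove an at least 8.3-fold lower number from compound 2 to compound 3 (0.92 log units; beyond the scatter), its number in this assay is expected to stay in the same region as compound 3, with a step of about a 1.6-fold higher number from compound 3 to compound 4 (0.19 log units; within the scatter). The estimate for compound 4 is 1500 nM, with a likely range from 500 nM to 5000 nM.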

Compound 4, half-maximal inhibitory concentration: 5420 nM
For compound 4 the middle estimate is 3.6-fold (0.56 log units) below the measured one; measured number outside the range, above it.
By their numbers in this assay, from the lowest: compound 3; then compound 1; then compound 4. At a limit, above all of these: compound 2.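

In this assay, the group at this place on the ring, para to a large group, turns out not to be a free choice: ethyl and methoxy both have 2 heavy atoms, one carbon giving way to an oxygen, yet the swap gives a 5.6-fold higher number from compound 3 to compound 4 (0.75 log units; beyond the scatter) and moves the number well away from that of the best compound. The aromatic ring on the amine nitrogen therefore does not hold the number down by itself, since the comparison with the dimethyl-substituted ring gives a 2.6-fold higher number from compound 1 to compound 4 (0.42 log units; beyond the scatter) and places the methoxy compound on the weaker side. The earlier advantage of an aromatic ring over benzyl is also not secured for this substituent, as an at least 1.4-fold lower number from compound 2 to compound 4 (0.16 log units; that floor lies within the scatter) rests on a limit rather than a number for compound 2: the limit of > 8000 nM in this assay, at which 1 of the 4 values shown sits.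

On these data alone, whether a hydroxyl, a chlorine or a propyl chain at this same place would sit nearer compound 3 or compound 4 stays open. The compounds shown also leave open whether an ethoxy group, which adds one carbon to the methoxy group, would recover any of the lost ground.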